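The source may hold more compounds than are shown below. What is called first, only, known or untested is meant among the compounds shown, and "the series" means these compounds.

Three compounds have been measured in an assay on isolated protein for inhibition of sphingomyelin phosphodiesterase (Homo sapiens), read by fluorescence, with a stated time of 30 min; on this read-out higher numbers stand for weaker inhibition and lower numbers for stronger inhibition:

Compound 1 `CCCCCCc1ccc(COc2cccc(C(=O)NO)c2)cc1` gives 2110 nM.
Compound 2 `O=C(NO)c1cccc(OCc2ccc(-c3noc(CCc4ccccc4)n3)cc2)c1` gives 1730 nM.
Compound 3 `O=C(NO)c1cc(OCc2ccc(-c3ccccc3)cc2)no1` gives 880 nM.

Compound 3 has the lowest number of the three. Its gap to compound 2 lies within the usual scatter of this assay, so the two cannot be ranked; its gap to compound 1 lies beyond it, so compound 3 is the more potent of that pair. Compound 4 `O=C(NO)c1cc(OCc2ccc(-c3ccc(Cl)cc3)cc2)no1` differs from compound 3 by a single change: chloro in place of hydrogen on an aromatic carbon. Within the data shown here, no pair of measured compounds shows this change, so there is nothing to lean on directly. The expectation is a small step toward a lower number, possibly none beyond the scatter, giving a 1.5-fold lower number from compound 3 to compound 4 (0.17 log units; within the scatter). Compound 4 is therefore estimated at 600 nM, with a range from 250 nM to 1500 nM.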

Compound 4, half-maximal inhibitory concentration: 320 nM
Compound 4: the middle estimate sits 1.9-fold (0.27 log units) above what was measured; low and high end bracket the measured number.
By their numbers in this assay, from the lowest: compound 4; then compounds 3, 2 and 1 (each within the scatter of the next, the first and the last beyond it).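

Replacing phenyl with 4-chlorophenyl gives a 2.8-fold lower number from compound 3 to compound 4 (0.44 log units; beyond the scatter) in this assay and is the first change in a single place that can be read among these compounds. It shows that this aromatic carbon, para to a large group, accepts chloro, and that this one heavy atom alone moves the number beyond the scatter. Nothing available accounts for the size of this step.

Going by these compounds, it remains open whether fluoro, methyl or methoxy in the same place would lower the number as far. On these data alone, it is also open whether chloro would give a similar step on the core of compound 1.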